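This account rests on a few compounds, and the source may have more. Where it says the series, first, only, none or still open, it means among the compounds named here.

Compound 1 `CCC(=O)N[C@@H]1CCCc2c1cncc2N1CCc2cc(Cl)ccc2C1=O`: < 3.5 mL/min/kg.
Compound 2 `CCC(=O)N[C@@H]1CCCc2c1cncc2N1Cc2cc(Cl)ccc2C1=O`: < 3.5 mL/min/kg.

In an ADME assay on microsomes from liver (Homo sapiens) for metabolic stability, read by LC-MS, using NADPH, with stated times of 10 min and 30 min (a lower number here means slower removal, a higher number faster removal of the compound), compound 1 gives < 3.5 mL/min/kg, which is a limit of the assay and not a number. Compound 2 likewise gives < 3.5 mL/min/kg, again a limit rather than a number. Compound 2 therefore stands at the limit of < 3.5 mL/min/kg in this assay, at which 2 of the 2 values shown sit. Compound 3 `CCC(=O)N[C@@H]1CCCc2c1cncc2N1C(=O)c2ccc(Cl)cc2[C@@H]1C` differs from compound 2 by methyl in place of hydrogen on a saturated ring carbon. Going by the values given here, no step between measured compounds is available, and no change beyond the usual scatter is expected in this assay. The expected step from this change is a step that the limit leaves unreadable from compound 2 to compound 3. The estimate for compound 3 is 3 mL/min/kg, ranging from 1.5 mL/min/kg to 6 mL/min/kg.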

Compound 3, clearance: < 3.5 mL/min/kg
Compound 3: a limit, no number (the forecaster's own chance of this, stated with the estimate: 65%); the middle value does not contradict the limit.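

The step from compound 2 to compound 3 cannot be read, as both results in this assay are limits and not numbers: the limit of < 3.5 mL/min/kg in this assay, at which 3 of the 3 values shown sit.

The compounds shown leave open how fast each is actually removed, and whether methyl in place of hydrogen changes that rate.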